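Enlarging a boron-bearing group on a shared core

The source may report more compounds than this note shows. Statements on the series, on what has been measured and on what is new or still open speak of the compounds shown alone.

In a functional assay on MDA-MB-435 cells (Homo sapiens) for inhibition (on this read-out higher numbers stand for weaker inhibition and lower numbers for stronger inhibition), compound 1 (`O=C(/C=C/c1ccc(F)c(Cl)c1)c1ccc(B(O)O)cc1`) gives 16000 nM and compound 3 (`O=C(/C=C/c1ccc(I)cc1)c1ccc(B(O)O)cc1`) gives 10000 nM on the same read-out, so these two lie within the usual scatter of each other. Compound 2 (`O=C(/C=C/c1ccc(I)cc1)c1ccc(O)cc1`) gives 4500 nM as its value, a clearly lower number than that of compound 3.

Compound 4 (`O=C(/C=C/c1ccc(I)cc1)c1ccc(OCB(O)O)cc1`) has not yet been measured. It differs from compound 3 in one place, with a group of 5 heavy atoms (1 carbon, 1 boron, 3 oxygen; no ring) in place of a group of 3 heavy atoms (1 boron, 2 oxygen; no ring), on an aromatic carbon as the change, on an aromatic carbon of a six-membered aromatic ring of carbon only, para to a large group. Compound 4 keeps the boron of compound 3 and, like compound 2, has an oxygen on that ring carbon.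

Among the measured compounds shown here, the one measured step bearing on this is a 2.2-fold higher number from compound 2 to compound 3 (0.35 log units; beyond the scatter) at that same ring carbon. It is modest, though beyond the scatter, and compound 4 shares features with both of its ends, so no step beyond the scatter is expected in this assay for this change. The estimated step is a 1.3-fold lower number from compound 3 to compound 4 (0.10 log units; within the scatter) and is only an expectation. Compound 4 is estimated at 8000 nM with an expected range from 3000 nM to 22000 nM across repeated measurements.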

Compound 4, half-maximal inhibitory concentration: 18000 nM
Compound 4: middle estimate off by 2.3-fold (0.35 log units), on the low side; low and high end bracket the measured number.
By their numbers in this assay, from the lowest: compound 2; then compounds 3, 1 and 4 (each within the scatter of the next).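

In this assay, the step of a 1.8-fold higher number from compound 3 to compound 4 (0.26 log units; within the scatter) shows that enlarging the boron-bearing group at this ring carbon, para to a large group, gives no change that can be told apart from repeat-measurement variation. The other new step tells a different story, since placing a boron-bearing group on the oxygen of compound 2 gives a 4.0-fold higher number from compound 2 to compound 4 (0.60 log units; beyond the scatter) and so an oxygen on that ring carbon does not by itself keep the lower number. At this position, then, both boron-bearing groups shown, in compound 3 and compound 4, give clearly higher numbers than the plain oxygen with its hydrogen in compound 2, and the oxygen added in compound 4 does not bring the value back toward that of compound 2.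

No measurement shown gives a reason for these results. On these data alone, it stays open how an amine, a carboxylic acid or a longer chain ending in boron would behave at this ring carbon, and whether the same steps would hold on the core of compound 1.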